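This account rests on a few compounds, and the source may have more. Where it says the series, first, only, none or still open, it means among the compounds named here.

Among the compounds with values here, the three compounds measured so far share one core and differ only in the group on the amide nitrogen. In an assay on cells for displacement of a labelled ligand from Neuronal acetylcholine receptor; alpha3/beta4 (Homo sapiens) (a higher number here means a weaker inhibitor, a lower number a stronger inhibitor), compound 1 `O=C(Nc1ccc(F)cc1F)c1cncc(N2CC3CC(C2)N3)c1` gives 50 nM, compound 2 `O=C(Nc1ccccc1F)c1cncc(N2CC3CC(C2)N3)c1` gives 102 nM and compound 3 `COc1cccc(NC(=O)c2cncc(N3CC4CC(C3)N4)c2)c1` gives 265 nM, the highest of the three numbers, with steps of a 2.0-fold higher number from compound 1 to compound 2 (0.31 log units; beyond the scatter), a 5.3-fold higher number from compound 1 to compound 3 (0.72 log units; beyond the scatter) and a 2.6-fold higher number from compound 2 to compound 3 (0.41 log units; beyond the scatter). Compound 4 `O=C(NCc1ccccc1)c1cncc(N2CC3CC(C2)N3)c1` carries benzyl in place of 3-methoxyphenyl on an amide-type nitrogen. All three measured steps bear on it, since each alters the group on that nitrogen, and each was modest. None of them exchanges an aromatic ring for a benzyl, so the direction is uncertain. Compound 4 is expected to give 400 nM in this assay, within 120 nM to 1300 nM, an expected step of a 1.5-fold higher number from compound 3 to compound 4 (0.18 log units; within the scatter).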

Compound 4, inhibition constant: 1600 nM
The estimate for compound 4 lay 4.0-fold (0.60 log units) below the measured number; the whole stated range lies below it.
By their numbers in this assay, from the lowest: compound 1; then compound 2; then compound 3; then compound 4.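

In this assay, within the data shown here, benzyl on the amide-type nitrogen brings a 6.0-fold higher number from compound 3 to compound 4 (0.78 log units; beyond the scatter) and a 16-fold higher number from compound 2 to compound 4 (1.20 log units; beyond the scatter) and a 32-fold higher number from compound 1 to compound 4 (1.51 log units; beyond the scatter), and the last two are the first steps at this position that rate as large. Among these compounds, this position therefore responds far more to the exchange of these aromatic groups for benzyl than the earlier compounds revealed, and compound 4 has the highest number of the four. No evidence is available to account for this result. As far as these compounds go, what remains open is whether a phenethyl group on that nitrogen would raise the number further, and whether fluoro or methoxy on the benzyl ring would lower it.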